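A few compounds are considered here, and "the series" means these few. Any claim that something is new, unique, unknown or untested is made for them only; others in the source may bear on it.

Compound 2, `Cc1cc(C)c(CN2CCc3c(Cl)cc([C@H](CO)[C@H]4CCCO4)c(Cl)c3C2=O)c(=O)[nH]1`, carries an oxolan-2-yl ring on a saturated chain carbon bound to an aromatic carbon and a saturated chain carbon. In an assay for inhibition of histone-lysine N-methyltransferase EZH2 variant Y641N (Homo sapiens), read by scintillation counting, with a stated time of 60 min, in the presence of a further agent that is not named here (a lower number here means a stronger inhibitor, a higher number a weaker inhibitor), compound 2 gives 8 nM, the highest of the two numbers recorded so far. For the measured compounds named here, its only measured neighbour is compound 1, `Cc1cc(C)c(CN2CCc3c(Cl)cc([C@H](CO)[C@H]4CCOC4)c(Cl)c3C2=O)c(=O)[nH]1`, which has oxolan-3-yl in that place; in this assay compound 1 gives 0.24 nM, and the step of a 33-fold higher number from compound 1 to compound 2 (1.52 log units; beyond the scatter) is large, well beyond the scatter. Compound 3, `Cc1cc(C)c(CN2CCc3c(Cl)cc([C@H](CO)[C@@H]4CCCO4)c(Cl)c3C2=O)c(=O)[nH]1`, has not yet been measured. (the two compounds have the same atoms and bonds and differ only in configuration as drawn: 1 of 2 stereo elements differ; a stereocentre at a saturated ring carbon is drawn R in compound 2 and S in compound 3). Going by the values given here, no measured step changes a configuration alone. Among the compounds with values here, the single step available, a 33-fold higher number from compound 1 to compound 2 (1.52 log units; beyond the scatter), concerns which ring carbon is attached to the chain, and it shows that this part of the molecule is sensitive to change without indicating the direction an epimer swap will take. The step of a 2.0-fold lower number from compound 2 to compound 3 (0.30 log units; within the scatter) is therefore estimated as a modest one, with both directions left open and a wide margin. Compound 3 is expected to give about 4 nM, within the range 0.5 nM to 30 nM.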

Compound 3, inhibition constant: 10 nM
The estimate for compound 3 lay 2.5-fold (0.40 log units) below the measured number, and the stated range covers the measured number.
By their numbers in this assay, from the lowest: compound 1; then compounds 2 and 3 (each within the scatter of the next).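

In this assay the step is a 1.3-fold higher number from compound 2 to compound 3 (0.10 log units; within the scatter), so the two drawn configurations of the saturated ring carbon in the oxolan-2-yl group cannot be told apart by this measurement. The large loss linked to oxolan-2-yl is therefore not confined to one configuration: the step of a 42-fold higher number from compound 1 to compound 3 (1.62 log units; beyond the scatter) is large, as is the step of a 33-fold higher number from compound 1 to compound 2 (1.52 log units; beyond the scatter), and compound 1 stands clearly apart from both of the other compounds. This reading of the stereocentre rests on a clean comparison, with no other structural difference to take into account: the fact that compounds 2 and 3 differ only in the configuration as drawn

The compounds shown leave open whether the oxolan-3-yl group is equally indifferent to configuration, since compound 1 represents only one drawn form of that ring, and a sensitivity there could differ from what is seen with oxolan-2-yl. They also leave open how this position would respond to a group other than an oxolane ring, such as a pyrrolidine ring, which carries an amine, or an open methoxyethyl chain.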